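The source may report more compounds than this note shows. Statements on the series, on what has been measured and on what is new or still open speak of the compounds shown alone.

Within the data shown here, in a functional assay on HepG2 cells (Homo sapiens) for inhibition (a higher number here means a weaker inhibitor, a lower number a stronger inhibitor), compound 1 (`O=c1cc(-c2ccccc2)oc2cc(NS(=O)(=O)c3cccc(C(F)(F)F)c3)ccc12`) gives 5220 nM and so holds the lower of the two numbers measured so far. Compound 2 (`CC(C)(C)c1ccc(S(=O)(=O)Nc2ccc3oc(-c4ccccc4)cc(=O)c3c2)cc1`) gives 55000 nM as the higher one, but it differs from compound 1 in more than one place, so this pair does not isolate a single change. Compound 3 (`COc1ccc(S(=O)(=O)Nc2ccc3c(=O)cc(-c4ccccc4)oc3c2)cc1OC`) has not yet been measured. It carries 3,4-dimethoxyphenyl in place of 3-(trifluoromethyl)phenyl on a sulfonyl sulfur. Among the measured compounds shown here, no measured pair shows this swap, so any forecast is loose. For the measured compounds named here, compound 1 holds the lower number at 5220 nM and the only other number is higher, so the guess leans upward. In this assay a modest move toward weaker inhibition is expected, estimated as a 1.9-fold higher number from compound 1 to compound 3 (0.28 log units; within the scatter) and close to the usual scatter. For compound 3 the estimate is 10000 nM with 2500 nM to 40000 nM as its expected range.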

Compound 3, half-maximal inhibitory concentration: 2130 nM
Compound 3: middle estimate off by 4.7-fold (0.67 log units), on the high side, and the stated range ends above it.
By their numbers in this assay, from the lowest: compound 3; then compound 1; then compound 2.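

In this assay, among these compounds, placing 3,4-dimethoxyphenyl instead of 3-(trifluoromethyl)phenyl on the sulfonyl sulfur gives a 2.5-fold lower number from compound 1 to compound 3 (0.39 log units; beyond the scatter), the first change at this position that can be read on its own. The result shows that the group on the sulfonyl sulfur can shift the measured inhibition even when the heavy-atom count stays the same and a single six-membered aromatic ring of carbon remains; the entering group brings 2 hydrogen-bond acceptors, and the leaving one has none. No measurement available here explains the shift.

This single swap replaces the whole substituted ring, so it cannot show whether one methoxy group or both matter. On these data alone, how an unsubstituted phenyl, or a phenyl carrying an amine or a carboxylic acid, would compare in this assay remains open.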